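This account rests on a few compounds, and the source may have more. Where it says the series, first, only, none or still open, it means among the compounds named here.

Measured compounds:

Compound 1, `CCC(NC(=S)NCc1ccc(C(C)(C)C)cc1)c1ccc(NS(C)(=O)=O)c(F)c1`: 54 nM
Compound 2, `CC(C)C(NC(=S)NCc1ccc(C(C)(C)C)cc1)c1ccc(NS(C)(=O)=O)c(F)c1`: 223 nM
Compound 3, `COc1cc(C(C)NC(=S)NCc2ccc(C(C)(C)C)cc2)ccc1NS(C)(=O)=O`: 28.6 nM

All three were tested in a functional assay on CHO cells for antagonist activity at transient receptor potential cation channel subfamily V member 1 (Rattus norvegicus); on this read-out lower numbers stand for stronger inhibition and higher numbers for weaker inhibition. Compound 1 and compound 2 share one core and differ in a single place: methyl in place of hydrogen on a saturated chain carbon bound to two saturated chain carbons. Along that step the read-out moved a 4.1-fold higher number from compound 1 to compound 2 (0.62 log units; beyond the scatter), so the added methyl weakened inhibition in this assay.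

Compound 3 carries a different core; the difference between the core of compound 3 and the core of compound 1 is not broken down here. In this assay compound 3 gives the lowest of the three numbers, though its gap to compound 1 lies within the scatter, so no order between those two can be read from the data, while its gap to compound 2 lies beyond the scatter.

Compound 4, `COc1cc(C(C)(C)NC(=S)NCc2ccc(C(C)(C)C)cc2)ccc1NS(C)(=O)=O`, has not yet been measured. It differs from compound 3 in one place: methyl in place of hydrogen on a saturated chain carbon bound to an amide-type nitrogen, an aromatic carbon and a saturated chain carbon. Among the measured compounds shown here, this is the same kind of change as the one from compound 1 to compound 2, but the surroundings differ: there the carbon was bound to two saturated chain carbons, here it is bound to an amide-type nitrogen, an aromatic carbon and a saturated chain carbon.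

Resting on the weakening seen as a 4.1-fold higher number from compound 1 to compound 2 (0.62 log units; beyond the scatter), a step of similar size is expected from compound 3 to compound 4, roughly a 4.2-fold higher number from compound 3 to compound 4 (0.62 log units; beyond the scatter). Compound 4 is therefore estimated at 120 nM in this assay, with a likely range from 40 nM to 400 nM.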

Compound 4, inhibition constant: 663 nM
For compound 4 the middle estimate is 5.5-fold (0.74 log units) below the measured one; measured number above the stated range.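

In this assay, putting methyl in place of hydrogen on a saturated chain carbon bound to an amide-type nitrogen, an aromatic carbon and a saturated chain carbon gave a 23-fold higher number from compound 3 to compound 4 (1.37 log units; beyond the scatter), a large weakening of inhibition. Among the compounds shown here, the earlier step ran in the same direction, so both examples of this change weaken inhibition, but its size did not carry over from one core to the other: the same change on two cores in this assay, a 4.1-fold higher number (0.62 log units; beyond the scatter) from compound 1 to compound 2 and a 23-fold higher number (1.37 log units; beyond the scatter) from compound 3 to compound 4, 5.6-fold (0.75 log units) apart, beyond the scatter of two such steps With only two such steps, which differ both in the core and in the surroundings of the carbon that takes the methyl, the data do not show which of these differences sets the size of the step, and they give no rule for how large it would be on any further core.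

The compounds shown leave open how the same change behaves when the core is held fixed and only the surroundings of that carbon vary. As far as these compounds go, it also remains open whether a group other than methyl, such as a hydroxyl group or a fluorine atom, would be tolerated better on the carbon bound to the amide-type nitrogen.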